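The compounds below may be only part of what the source reports. "The series", "measured", "known", "first", "only" and "open" are said of these compounds alone.

Compounds 1, 2 and 3 share one core and differ only in the group carried on a saturated chain carbon bound to an amide-type nitrogen. Compound 3 `CCCNC(=O)c1cc2nc(C)c([C@H](OC(C)(C)C)C(=O)O)c(-c3cc(F)c4c(c3C)CCCO4)n2n1` stands at a limit in an ADME assay on MT2 cells (Homo sapiens) for cytotoxicity; on this read-out higher numbers stand for lower toxicity in this test and lower numbers for higher toxicity in this test: compound 3 gives > 40000 nM, which is a limit of the assay and not a number. Compound 2 `CNC(=O)c1cc(F)ccc1CNC(=O)c1cc2nc(C)c([C@H](OC(C)(C)C)C(=O)O)c(-c3cc(F)c4c(c3C)CCCO4)n2n1` likewise gives > 40000 nM, again a limit. Compound 1 `CCCc1cc(CNC(=O)c2cc3nc(C)c([C@H](OC(C)(C)C)C(=O)O)c(-c4cc(F)c5c(c4C)CCCO5)n3n2)ccc1F` gives > 20000 nM, also a limit. Because two of the three values sit at the limit of > 40000 nM in this assay, at which 2 of the 3 values shown sit, and the third at the limit of > 20000 nM in this assay, at which 1 of the 3 values shown sits, none of the steps between them can be read: a step that the two limits leave unreadable from compound 1 to compound 3, a step that the two limits leave unreadable from compound 2 to compound 3 and a step that the two limits leave unreadable from compound 1 to compound 2. Compound 4 `Cc1nc2cc(C(=O)NCCC3CCCCC3)nn2c(-c2cc(F)c3c(c2C)CCCO3)c1[C@H](OC(C)(C)C)C(=O)O` differs from compound 3 by cyclohexyl in place of methyl on a saturated chain carbon, two bonds along the chain from an amide-type nitrogen. Those three unreadable steps are all that bears on this change, and they fix neither a size nor a direction for the step in this assay. Compound 4 is therefore expected to stay at a limit, the estimated step being a number no higher from compound 3 to compound 4 (the limit leaves the size open). Compound 4 is expected to give about 40000 nM, estimated between 20000 nM and 80000 nM.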

Compound 4, half-maximal cytotoxic concentration: > 40000 nM
Compound 4 ended at the assay's limit; the forecaster's own chance of this, stated with the estimate: 85%; the middle value lies on the limit itself.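

In this assay compound 4 gives > 40000 nM, a limit and not a number. Among the compounds shown here, no step from compound 1, compound 2 or compound 3 to compound 4 can be read. The compounds shown leave open whether these four groups differ at all in this assay, and in which direction.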